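This account rests on a few compounds, and the source may have more. Where it says the series, first, only, none or still open, it means among the compounds named here.

Values in a functional assay on Raji cells (Homo sapiens) for inhibition, read by MTT assay, with a stated time of 96 h; on this read-out lower numbers stand for an effect already at smaller amounts and higher numbers for an effect only at larger amounts of compound:
- compound 1 `CC(C)Cn1c(=O)n(C)c(=O)c2c1nc(Cc1cccc3ccccc13)c(=O)n2CCCCCCO`: > 10000 nM (a limit)
- compound 2 `CC(C)Cn1c(=O)n(C)c(=O)c2nc(SCCCCO)c(Cc3cccc4ccccc34)nc21`: 37 nM
- compound 3 `CC(C)Cn1c(=O)n(C)c(=O)c2nc(C(=O)N(C)CCCO)c(Cc3cccc4ccccc34)nc21`: > 10000 nM (a limit)

Compound 2 alone carries an actual number, and the other two stop at the limit of > 10000 nM in this assay, at which 2 of the 3 values shown sit. Its standing therefore rests on one value, with nothing measured on either side of it.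

Compound 4 `CC(C)Cn1c(=O)n(C)c(=O)c2nc(CCCCCCO)c(Cc3cccc4ccccc34)nc21` has 6-hydroxyhexyl in place of the (4-hydroxybutyl)sulfanyl of compound 2 on an aromatic carbon, ortho to a (naphthalen-1-yl)methyl group (6-hydroxyhexyl in place of (4-hydroxybutyl)sulfanyl on an aromatic carbon).

Among the compounds with values here, the one measured step at this place is an at least 270-fold higher number from compound 2 to compound 3 (2.43 log units; beyond the scatter), with (3-hydroxypropyl)(methyl)carbamoyl replacing the same (4-hydroxybutyl)sulfanyl. That large step shows how far the number can move with a change here, but it does not set the size of this one. Compound 1 differs from compound 2 in more than one place, so it offers no clean comparison.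

The new group, like the old one, is an open chain without a ring and ends in a hydroxy group, whereas the group in compound 3 is a carbamoyl. Within the data shown here, a far smaller step than the one to compound 3 is therefore expected, probably towards a somewhat higher number, and it may not exceed the scatter. The expected change is a 1.6-fold higher number from compound 2 to compound 4 (0.21 log units; within the scatter).

In this assay the estimate for compound 4 is 60 nM, with an expected range from 12 nM to 600 nM.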

Compound 4, half-maximal effective concentration: 1690 nM
Compound 4: middle estimate off by 28-fold (1.45 log units), on the low side; the measured number lies above the stated range.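

At this aromatic carbon, an open chain ending in a hydroxy group is not enough to keep the low number: in this assay, 6-hydroxyhexyl in place of (4-hydroxybutyl)sulfanyl gives a 46-fold higher number from compound 2 to compound 4 (1.66 log units; beyond the scatter), a large step even though neither group has a ring. This exchange removes the sulfur and alters the chain at once, so the step cannot be assigned to either change alone. Against the (3-hydroxypropyl)(methyl)carbamoyl group, the 6-hydroxyhexyl chain gives an at least 5.9-fold lower number from compound 3 to compound 4 (0.77 log units; beyond the scatter), so the position also tells these two groups apart, but that step is only a bound resting on a limit: the limit of > 10000 nM in this assay, at which 2 of the 4 values shown sit.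

Going by these compounds, whether a (4-hydroxybutyl)oxy group, with oxygen in place of the sulfur, or a (6-hydroxyhexyl)sulfanyl group would stay close to compound 2 remains open. The compounds shown also do not tell what a chain ending in an amine or a carboxylic acid would do at this position.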